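Replacing the Aryl Group on an Aromatic Nitrogen

The compounds below may be only part of what the source reports. "The series", "measured", "known", "first", "only" and "open" are said of these compounds alone.

In a functional assay on A549 cells (Homo sapiens) for antiproliferative activity, read by MTT assay, with a stated time of 72 h (a lower number here means a stronger inhibitor, a higher number a weaker inhibitor), compound 1 (`CCNC(=O)c1cc(Oc2ccc(NC(=O)c3nn(-c4ccc(Br)cc4F)c(=O)cc3C)cc2)ccn1`) gives 34500 nM. Compound 3 (`CCNC(=O)c1cc(Oc2ccc(NC(=O)c3nn(-c4ccccc4C)c(=O)cc3C)cc2)ccn1`) gives 34800 nM, and compound 2 (`CCCNC(=O)c1cc(Oc2ccc(NC(=O)c3nn(-c4ccc(C)cc4)c(=O)cc3C)cc2F)ccn1`) gives 18000 nM. Compound 1 therefore stands within the scatter of both other measured compounds, and these three numbers set no real order among them.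

The unmeasured compound 4 (`CCNC(=O)c1cc(Oc2ccc(NC(=O)c3nn(-c4cccc(F)c4)c(=O)cc3C)cc2)ccn1`) has 3-fluorophenyl in place of 4-bromo-2-fluorophenyl on an aromatic nitrogen. The rest of the core of compound 1 stays as it is.

One measured step changes the group at this same place. It brings in 2-methylphenyl in place of 4-bromo-2-fluorophenyl, and it amounts to a 1.0-fold higher number from compound 1 to compound 3 (0.00 log units; within the scatter). For the measured compounds named here, compound 2 differs from compound 1 in more than one place, so it offers no clean step for this comparison. Going by the values given here, the evidence is thin, since it rests on a single step and no measured compound carries 3-fluorophenyl. Still, that one step gives no reason to expect a shift beyond the scatter in this assay.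

The expected step is small and lies within the scatter: a 1.2-fold lower number from compound 1 to compound 4 (0.06 log units; within the scatter). The estimate for compound 4 is 30000 nM, with an expected range of 14000 nM to 65000 nM.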

Compound 4, half-maximal inhibitory concentration: 7410 nM
Estimate against measurement, compound 4: 4.0-fold (0.61 log units) above; measured number below the stated range.
By their numbers in this assay, from the lowest: compound 4; then compounds 2, 1 and 3 (each within the scatter of the next).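

The group on the aromatic nitrogen turns out to matter in this assay: 3-fluorophenyl brings a modest but real change from 4-bromo-2-fluorophenyl (a 4.7-fold lower number from compound 1 to compound 4 (0.67 log units; beyond the scatter)), whereas the earlier exchange at this place, for 2-methylphenyl, had stayed within the scatter. The step against that 2-methylphenyl group is of the same size (a 4.7-fold lower number from compound 3 to compound 4 (0.67 log units; beyond the scatter)), so among these three compounds, which share the rest of the core, 3-fluorophenyl stands apart from two groups that cannot be told apart from each other. Nothing available bears on why the number falls with this change.

From the compounds shown here alone, whether plain phenyl, 3-chlorophenyl or 3-methoxyphenyl would sit with compound 4 or with compounds 1 and 3 stays open, and with it whether the lower number goes with the fluorine on the ring or with the loss of the other groups. Also open, going by these compounds, is whether 3-fluorophenyl would bring a similar step on the core of compound 2, which differs from compound 4 in more than one place.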